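Ethylsulfamoyl for dimethylamino on the shared core

This account rests on a few compounds, and the source may have more. Where it says the series, first, only, none or still open, it means among the compounds named here.

Measured compounds:
compound 1 `CCCS(=O)(=O)Nc1ccc(F)c(C(=O)c2n[nH]c3ncc(-c4ccc(N(C)C)cc4)cc23)c1F`, 2.5%
compound 2 `CCCS(=O)(=O)Nc1ccc(F)c(C(=O)c2n[nH]c3ncc(-c4ccc(OC)cc4Cl)cc23)c1F`, 5.3%

In an assay for binding affinity to dual specificity mitogen-activated protein kinase kinase 4 (Homo sapiens), read by KINOMEscan, tested at 100 nM (a lower number here means a stronger effect, a higher number a weaker effect of the compound at the concentration tested), compound 1 gives the lowest of the two numbers; the nearest is compound 2, with a number 2.8 percentage points higher from compound 1 to compound 2 (within the scatter). Compound 3 `CCCS(=O)(=O)Nc1ccc(F)c(C(=O)c2n[nH]c3ncc(-c4ccc(S(=O)(=O)NCC)cc4)cc23)c1F` carries ethylsulfamoyl in place of dimethylamino on an aromatic carbon. Among the measured compounds shown here, only one measured step, the one from compound 1 to compound 2, bears on this change, and it stays within the scatter; no step for ethylsulfamoyl itself is at hand. A modest rise at most is therefore expected, a number 5.5 percentage points higher from compound 1 to compound 3 (within the scatter). Compound 3 is estimated at 8%, between 1% and 35%.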

Compound 3, a percentage reported as activity, at one concentration (the size of the read-out at that concentration, not a potency): 3%
Beside the measured number, compound 3's estimate is 5 percentage points above it, and the stated range covers the measured number.
By their numbers in this assay, from the lowest: compounds 1, 3 and 2 (each within the scatter of the next).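

At this place on the aromatic ring, para to a large group, this assay does not separate ethylsulfamoyl from dimethylamino (a number 0.5 percentage points higher from compound 1 to compound 3 (within the scatter)), even though the entering group brings a hydrogen-bond donor and more heavy atoms. It does not separate 4-(ethylsulfamoyl)phenyl from 2-chloro-4-methoxyphenyl either (a number 2.3 percentage points lower from compound 2 to compound 3 (within the scatter)). No supporting evidence bears on why these numbers stay together.

Still open, from the compounds shown here alone, is whether a carboxylic acid or a primary amine at this place, or a longer chain on the sulfamoyl nitrogen, would shift the number beyond the scatter.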